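Oxadiazole side-chain swap: amine to piperidinylmethoxy

The source may hold more compounds than are shown below. What is called first, only, known or untested is meant among the compounds shown, and "the series" means these compounds.

The series shares one core and varies the substituent on the five-membered aromatic ring with 2 nitrogen and 1 oxygen. Compound 1 `CC(C)c1c(-c2nnc(NCCO)o2)cn2ncnc(Nc3cc(C(=O)NC4CC4)c(F)cc3F)c12` carries a hydroxyethylamino group there; in a functional assay on HUVEC cells (Homo sapiens) for antiproliferative activity (a higher number here means a weaker inhibitor, a lower number a stronger inhibitor), compound 1 gives 140 nM. Among the compounds with values here, compound 2 `CC(C)c1c(-c2nnc(NCC(C)(C)N)o2)cn2ncnc(Nc3cc(C(=O)NC4CC4)c(F)cc3F)c12` carries the (2-amino-2-methylpropyl)amino group; in this assay compound 2 gives "not determined" (no result reported), so no number stands for compound 2 and no step from it can be computed.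

Compound 3 `CC(C)c1c(-c2nnc(OCC3CCNCC3)o2)cn2ncnc(Nc3cc(C(=O)NC4CC4)c(F)cc3F)c12` is the next member. The change from compound 2 to compound 3 is (piperidin-4-yl)methoxy in place of (2-amino-2-methylpropyl)amino on an aromatic carbon. The single measured point, compound 1 at 140 nM, is the only anchor for the series, and the entering group differs from both measured side chains in ring content and in donor count.

With no measured step available, no direction is expected beyond the scatter of this assay; the working assumption is that compound 3 stays in the range shown by compound 1. Compound 3 is therefore expected at about 160 nM in this assay, with a range from 40 nM to 600 nM.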

Compound 3, half-maximal inhibitory concentration: 25 nM
The estimate for compound 3 lay 6.4-fold (0.81 log units) above the measured number, outside the stated range (below it).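

In this assay, putting (piperidin-4-yl)methoxy in place of (2-hydroxyethyl)amino on an aromatic carbon of the five-membered aromatic ring with 2 nitrogen and 1 oxygen gives a 5.6-fold lower number from compound 1 to compound 3 (0.75 log units; beyond the scatter). Within the data shown here, this is the first readable step: it shows that the number responds to the side chain at this position, and that a side chain carrying a six-membered non-aromatic ring is accepted there with a stronger result than the open hydroxyethylamino chain. No supporting evidence bears on the reason for this step, and compound 2 has no number, so no step to or from compound 2 can be read.

The step from compound 1 to compound 3 changes the linking atom and the ring-bearing chain together, so the compounds shown cannot assign the difference to either one; a (piperidin-4-yl)methylamino group on the same carbon, keeping the ring with a nitrogen link, would separate the two. Going by these compounds, it also remains open whether the ring nitrogen of the piperidine matters, which a cyclohexylmethoxy group would test.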